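Swapping 4-methylphenyl for 2-methoxyphenyl on the shared core

The compounds below may be only part of what the source reports. "The series", "measured", "known", "first", "only" and "open" are said of these compounds alone.

Of the compounds shown here, three on the shared core have been read in a functional assay on the whole organism for inhibition, with Rattus norvegicus as the target; on this read-out lower numbers stand for an effect already at smaller amounts and higher numbers for an effect only at larger amounts of compound. Compound 1 `CC(C)c1ccc(OC(C)(Cc2ccccc2)C(=O)O)cc1` gives > 10 mg/kg, which is a limit of the assay. Compound 2 `CC(C)c1ccc(OC(C)(Cc2cccc(Cl)c2)C(=O)O)cc1` gives a measured 5 mg/kg. From the compounds shown here alone, compound 3 `Cc1ccc(CC(C)(Oc2ccc(C(C)C)cc2)C(=O)O)cc1` gives < 1 mg/kg, which is also a limit, so its true position is unknown, though it has the lowest reading of the three.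

Compound 4 `COc1ccccc1CC(C)(Oc1ccc(C(C)C)cc1)C(=O)O` differs from compound 3 as follows: 2-methoxyphenyl in place of 4-methylphenyl on a saturated chain carbon, two bonds along the chain from a carbonyl carbon and an oxygen on an aromatic ring. This places 2-methoxyphenyl in place of 4-methylphenyl on a saturated chain carbon, two bonds along the chain from a carbonyl carbon and an oxygen on an aromatic ring.

Among the measured compounds shown here, three measured steps bear on this change. Chloro in place of hydrogen gave an at least 2.0-fold lower number from compound 1 to compound 2 (0.30 log units; that floor lies within the scatter), and methyl in place of hydrogen gave an at least 10-fold lower number from compound 1 to compound 3 (1.00 log units; beyond the scatter). The exchange of groups closest to the one planned here gave an at least 5.0-fold lower number from compound 2 to compound 3 (0.69 log units; beyond the scatter). The read-out therefore responds to substitution on this ring, and compound 3 holds the lowest reading. For the measured compounds named here, no compound with a methoxy group has been read.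

A move to a higher number is expected, with its size left uncertain by the limit at the start: an at least 3.0-fold higher number from compound 3 to compound 4 (0.47 log units; beyond the scatter). The estimate for compound 4 is 3 mg/kg, with an expected range of 0.8 mg/kg to 10 mg/kg.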

Compound 4, dose for half-maximal effect: > 10 mg/kg
Compound 4 gave a limit, no number; the forecaster's own chance of this, stated with the estimate: 30%; middle value at least 3.3-fold (0.52 log units) away from the limit.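

Exchanging 4-methylphenyl for 2-methoxyphenyl on the saturated chain carbon gives an at least 10-fold higher number from compound 3 to compound 4 (1.00 log units; beyond the scatter) in this assay, so the low reading of compound 3 does not carry over to every substituted phenyl at this position. Measured against 3-chlorophenyl, the same group gives an at least 2.0-fold higher number from compound 2 to compound 4 (0.30 log units; that floor lies within the scatter), and with that floor inside the scatter, no order between these two compounds can be claimed. The step between compound 1 and compound 4 cannot be read, both compounds standing at the same limit: the limit of > 10 mg/kg in this assay, at which 2 of the 4 values shown sit.

Compound 4 differs from compound 3 in both the substituent and its place on the ring, so the compounds shown do not separate the effect of the methoxy group from that of its placement. From the compounds shown here alone, how a hydroxy group, a fluoro group or an amine on this ring would read in this assay remains open, as does the true size of the gap between compound 3 and compound 4, which have limits at both ends of the step.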